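This account rests on a few compounds, and the source may have more. Where it says the series, first, only, none or still open, it means among the compounds named here.

Notes on the series. Compound 1 `O=Cc1ccc(-c2cn3ccnc3c(-c3ccc4ncn(C5CCCCC5)c4c3)n2)cc1` gives 49.1% in a functional assay on HCT-15 cells (Homo sapiens) for inhibition, read by sulforhodamine B assay, with a stated time of 48 h, tested at 10 uM; on this read-out higher numbers stand for more inhibition at the one concentration tested (going by the name of the read-out) and lower numbers for less inhibition. Compound 2 `c1cn2cc(-c3ccsc3)nc(-c3ccc4ncn(C5CCCCC5)c4c3)c2n1` gives 1.37% and is the lower of the two numbers; the step of a number 47.7 percentage points lower from compound 1 to compound 2 (beyond the scatter) is large. Compound 3 `CC(=O)c1ccc(-c2cn3ccnc3c(-c3ccc4ncn(C5CCCCC5)c4c3)n2)cc1` is not yet measured; it differs from compound 2 by 4-acetylphenyl in place of thiophen-3-yl on an aromatic carbon. Among the compounds with values here, the only step that bears on this change is the one from compound 1 to compound 2, where swapping 4-formylphenyl for thiophen-3-yl cost heavily. Compound 3 carries a 4-acetylphenyl group, close in kind to the 4-formylphenyl of compound 1, so a large upward step a number 38.6 percentage points higher from compound 2 to compound 3 (beyond the scatter) is expected. Compound 3 is estimated at 40%, range 15% to 60%.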

Compound 3, a percentage reported as inhibition, at one concentration (the size of the read-out at that concentration, not a potency): 18.8%
Beside the measured number, compound 3's estimate is 21.2 percentage points above it; the measured number falls inside the stated range.
By their numbers in this assay, from the lowest: compound 2; then compound 3; then compound 1.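

In this assay, 4-acetylphenyl in place of thiophen-3-yl gives only a number 17.4 percentage points higher from compound 2 to compound 3 (beyond the scatter), while methyl in place of hydrogen on the carbonyl carbon gives a number 30.3 percentage points lower from compound 1 to compound 3 (beyond the scatter). At this position, then, a carbonyl-bearing six-membered aromatic ring does not by itself hold the level of compound 1; the group on the carbonyl carbon also counts. Nothing available explains this. Still open, from the compounds shown here alone, is how an amide or a carboxylic acid would read at that carbonyl carbon, and where an unsubstituted phenyl ring would fall.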